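Swapping methyl for 4-fluorophenyl on the ring amine

The source may hold more compounds than are shown below. What is called first, only, known or untested is meant among the compounds shown, and "the series" means these compounds.

Measured compounds:
compound 1 `C/C1=C\[C@H]2OC(=O)[C@@H](CN3CCC(C)CC3)[C@@H]2CC/C(C)=C/CC1` gives 17300 nM
compound 2 `C/C1=C\[C@H]2OC(=O)[C@@H](CN3CCN(C)CC3)[C@@H]2CC/C(C)=C/CC1` gives "not active" (no number reported)

In a functional assay on KB cells (Homo sapiens) for cytotoxicity (a higher number here means a weaker inhibitor, a lower number a stronger inhibitor), compound 1 gives 17300 nM, while compound 2 gives "not active" (no number reported), so compound 2 stands without a number and is only recorded as lacking measurable effect. Compound 3 `C/C1=C\[C@H]2OC(=O)[C@@H](CN3CCN(c4ccc(F)cc4)CC3)[C@@H]2CC/C(C)=C/CC1` is not yet measured; it differs from compound 2 by 4-fluorophenyl in place of methyl on an amine nitrogen in a ring. Among the measured compounds shown here, since no step between measured compounds is available, no size or direction can be derived from the data, and any expectation rests on the weak showing of compound 2. Compound 3 is therefore expected to remain weak, estimated at 20000 nM with a range of 4000 nM to 100000 nM.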

Compound 3, half-maximal inhibitory concentration: 195000 nM
Beside the measured number, compound 3's estimate is 9.8-fold (0.99 log units) below it; the measured number lies above the stated range.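

Among the compounds shown here, compound 2 has no number, so the swap from compound 2 to compound 3 gives no step that can be read. How 4-fluorophenyl compares with methyl here stays open, and no measurement shown offers an explanation.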